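Amide aryl swap on a shared core: from methoxyphenyl to pyridyl

The source may hold more compounds than are shown below. What is called first, only, known or untested is meant among the compounds shown, and "the series" means these compounds.

Measured so far:
Compound 1, `COc1cc2c(cc1OC)C(CC(=O)Nc1ccc(Cl)cc1)CC2`, gives 70% in a functional assay on the whole organism (strain Wistar) for inhibition, with Rattus norvegicus as the target, read by paw edema, with a stated time of 24 h, at a dose of 100 mg/kg; a lower number here means less inhibition, a higher number more inhibition at the dose given (going by the name of the read-out).
Compound 2, `COc1ccccc1NC(=O)CC1CCc2cc(OC)c(OC)cc21`, gives 30% in this assay.

Of the two numbers shown, compound 2 is the lower: the only step measured, a number 40 percentage points lower from compound 1 to compound 2 (beyond the scatter), takes the read-out down by an amount beyond the scatter when the group on the amide-type nitrogen changes. Compound 3, `COc1cc2c(cc1OC)C(CC(=O)Nc1ccncc1)CC2`, has not been measured. It differs from compound 2 at that same place, (pyridin-4-yl in place of 2-methoxyphenyl on an amide-type nitrogen).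

Among the measured compounds shown here, the one measured step bears on this change only in showing that the group on the amide-type nitrogen can move the read-out a long way in either direction. For the measured compounds named here, no pair with a pyridin-4-yl group has been measured, so the direction of the new step cannot be read from the numbers. Compound 3 is therefore expected to land somewhere between the two measured values, with a number 15 percentage points higher from compound 2 to compound 3 (beyond the scatter) as the estimated step. For compound 3 the estimate is 45%, with a range from 15% to 75%.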

Compound 3, a percentage reported as inhibition, in the whole organism at one dose (the size of the read-out at that dose, not a potency): 46.7%
Compound 3: middle estimate off by 1.7 percentage points, on the low side, and the stated range covers the measured number.
By their numbers in this assay, from the lowest: compound 2; then compound 3; then compound 1.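

In this assay, the pyridin-4-yl group on the amide-type nitrogen gives a number 16.7 percentage points higher from compound 2 to compound 3 (beyond the scatter), and a number 23.3 percentage points lower from compound 1 to compound 3 (beyond the scatter). The three groups at this place therefore give three separate levels of inhibition, so a ring with a nitrogen in it keeps part of the effect and places the compound in the middle of the set, rather than at either measured extreme. The change from 2-methoxyphenyl also does several things at once: it removes the methoxy group, puts a nitrogen into the ring and leaves fewer heavy atoms, so the step cannot be assigned to any one of these. Nothing measured here explains why the three groups differ.

What the compounds shown leave open is how much of the step comes from the ring nitrogen itself, a question that an unsubstituted phenyl group at the same place would help to separate. Also open, from the compounds shown here alone, is whether the location of that nitrogen matters, as a pyridin-3-yl group would show, and whether the aromatic ring is needed at all, as a piperidin-4-yl group would show.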